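The source may report more compounds than this note shows. Statements on the series, on what has been measured and on what is new or still open speak of the compounds shown alone.

Compound 2 `CCC(C)Nc1[nH]c(C)nc2nccc1-2` stands as the lower of two numbers in a functional assay on the whole organism for inhibition, with Nicotiana tabacum as the target (on this read-out higher numbers stand for weaker inhibition and lower numbers for stronger inhibition), where compound 2 gives 174000000 nM. Compound 1 `Cc1nc2nccc-2c(NC(C)C)[nH]1` gives 550000000 nM in this assay. Among the compounds with values here, the one measured step is a 3.2-fold lower number from compound 1 to compound 2 (0.50 log units; beyond the scatter), a gain from adding a methyl to the chain. Compound 3 `Cc1nc2nccc-2c(NCC(C)O)[nH]1` differs from compound 2 by 2-hydroxypropyl in place of sec-butyl on a nitrogen on an aromatic ring. That measured step does not cover a change that removes the methyl-bearing chain and brings in a hydroxyl group, so it offers only weak guidance. In this assay the step is expected to read a 1.7-fold higher number from compound 2 to compound 3 (0.24 log units; within the scatter). Compound 3 is therefore estimated at 300000000 nM, within a range from 80000000 nM to 1200000000 nM.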

Compound 3, half-maximal inhibitory concentration: 30200000 nM
Compound 3: middle estimate off by 9.9-fold (1.00 log units), on the high side; the whole stated range lies above it.
By their numbers in this assay, from the lowest: compound 3; then compound 2; then compound 1.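

In this assay, 2-hydroxypropyl in place of sec-butyl on this nitrogen gives a 5.8-fold lower number from compound 2 to compound 3 (0.76 log units; beyond the scatter) with the heavy-atom count unchanged, so at this position the number depends on more than chain size. The same group in place of isopropyl gives an 18-fold lower number from compound 1 to compound 3 (1.26 log units; beyond the scatter) and places the hydroxyl-bearing chain lowest of the three. Nothing available explains why this chain reads lower. Still open, on these data alone, is whether the hydroxyl itself matters, or whether a methoxy or an amine in its place would read the same.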